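A few compounds are considered here, and "the series" means these few. Any claim that something is new, unique, unknown or untested is made for them only; others in the source may bear on it.

For the measured compounds named here, compound 1 `O=S(=O)(Nc1ccc(Cl)cc1Cl)c1ccc(-c2cnc(C3CC3)o2)cc1` gives 74500 nM in a functional assay on cells (leukaemia cell line, Homo sapiens) for inhibition, read by sulforhodamine B assay, with a stated time of 48 h (a lower number here means a stronger inhibitor of growth, a higher number a weaker inhibitor of growth), the highest of the two numbers measured so far. Compound 2 `O=S(=O)(Nc1ccc(F)c(Cl)c1)c1ccc(-c2cnc(C3CC3)o2)cc1` gives 73700 nM in this assay, and the step of a 1.0-fold lower number from compound 1 to compound 2 (0.00 log units; within the scatter) lies within the scatter. Compound 3 `O=S(=O)(Nc1ccc(Br)c(Cl)c1)c1ccc(-c2cnc(C3CC3)o2)cc1` has not yet been measured; it differs from compound 1 by 4-bromo-3-chlorophenyl in place of 2,4-dichlorophenyl on a sulfonamide nitrogen. Going by the values given here, the only measured step that also swaps the ring on the sulfonamide nitrogen, a 1.0-fold lower number from compound 1 to compound 2 (0.00 log units; within the scatter), changed nothing, so no step beyond the scatter is expected in this assay, and a 1.0-fold lower number from compound 1 to compound 3 (0.00 log units; within the scatter) is the expected outcome. Compound 3 is estimated at 74000 nM, within a range from 30000 nM to 150000 nM.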

Compound 3, concentration for total growth inhibition: 70300 nM
Compound 3: the middle estimate sits 1.1-fold (0.02 log units) above what was measured, and the stated range covers the measured number.
By their numbers in this assay, from the lowest: compounds 3, 2 and 1 (each within the scatter of the next).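

In this assay the change to 4-bromo-3-chlorophenyl on a sulfonamide nitrogen gives a 1.1-fold lower number from compound 1 to compound 3 (0.03 log units; within the scatter) and bromo in place of fluoro on an aromatic carbon gives a 1.0-fold lower number from compound 2 to compound 3 (0.02 log units; within the scatter). Both steps lie within the scatter, so this position has now taken three different halogen-bearing phenyl groups without a readable change, and swapping a single halogen changes no more than swapping the whole ring did. No supporting measurement offers an explanation for this. The compounds shown leave open whether a phenyl ring carrying an amine or a carboxylic acid would move the number at this position.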